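A few compounds are considered here, and "the series" means these few. Any claim that something is new, unique, unknown or untested is made for them only; others in the source may bear on it.

Measured so far:
Compound 1, `CCCCCCCCCCCCCCOC(=O)CCC(=O)N1CCN(CCCOc2cc3c(Nc4ccc(F)c(Cl)c4)ncnc3cc2OC)CC1`: 77.2%
Compound 2, `CCCCCCCCCCCCCCCOC(=O)CCC(=O)N1CCN(CCCOc2cc3c(Nc4ccc(F)c(Cl)c4)ncnc3cc2OC)CC1`: 81.1%
Compound 3, `CCCCCCCCCCCCCCCCCOC(=O)CCC(=O)N1CCN(CCCOc2cc3c(Nc4ccc(F)c(Cl)c4)ncnc3cc2OC)CC1`: 83.2%

All three numbers come from a functional assay on A549 cells (Homo sapiens) for cytotoxicity, read by MTT assay, with a stated time of 24 h, tested at 80 uM; a higher number here means a weaker effect of the compound at the concentration tested, a lower number a stronger effect. The compounds share one core and differ only along the saturated chain. From compound 1 to compound 2 the change is methyl in place of hydrogen on a saturated chain carbon, ten or more bonds along the chain from an oxygen next to a carbonyl group, and the step it made is a number 3.9 percentage points higher from compound 1 to compound 2 (within the scatter). The onward step is a number 2.1 percentage points higher from compound 2 to compound 3 (within the scatter), and across both, a number 6 percentage points higher from compound 1 to compound 3 (within the scatter). None of these gaps is beyond the scatter, so no order among compound 1, compound 2 and compound 3 can be read from them.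

Compound 4, `CCCCCCCCCCCCCCCCCCOC(=O)CCC(=O)N1CCN(CCCOc2cc3c(Nc4ccc(F)c(Cl)c4)ncnc3cc2OC)CC1`, has not yet been tested in this assay. It stands to compound 3 as compound 2 stands to compound 1: the change is methyl in place of hydrogen on a saturated chain carbon, ten or more bonds along the chain from an oxygen next to a carbonyl group, the same change as from compound 1 to compound 2, and the place is the same word for word. The cores of compound 1 and compound 3 differ by propyl in place of hydrogen on a saturated chain carbon, ten or more bonds along the chain from an oxygen next to a carbonyl group.

The expectation for compound 4 rests on compound 1 and compound 2, whose step a number 3.9 percentage points higher from compound 1 to compound 2 (within the scatter) was within the scatter, and on compound 3 at 83.2%. For compound 4 the expected step is a number 1.3 percentage points higher from compound 3 to compound 4 (within the scatter). Compound 4 is estimated at 84.5%, with a range from 76% to 93%.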

Compound 4, a percentage reported as activity, at one concentration (the size of the read-out at that concentration, not a potency): 86.7%
Compound 4: middle estimate off by 2.2 percentage points, on the low side; measured number inside the range.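

Methyl in place of hydrogen on a saturated chain carbon gives in this assay a number 3.5 percentage points higher from compound 3 to compound 4 (within the scatter), in agreement with the same change on the other core: the same change on two cores in this assay, a number 3.9 percentage points higher (within the scatter) from compound 1 to compound 2 and a number 3.5 percentage points higher (within the scatter) from compound 3 to compound 4, 0.4 percentage points apart, within the scatter of two such steps

Propyl in place of hydrogen at that place reads the same way, with a number 5.6 percentage points higher from compound 2 to compound 4 (within the scatter) set against the earlier propyl step: the same change on two cores in this assay, a number 6 percentage points higher (within the scatter) from compound 1 to compound 3 and a number 5.6 percentage points higher (within the scatter) from compound 2 to compound 4, 0.4 percentage points apart, within the scatter of two such steps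

The change therefore carries between these cores without a visible difference, but every step is small, including a number 9.5 percentage points higher from compound 1 to compound 4 (within the scatter) for butyl in place of hydrogen, so this is agreement among steps within the scatter and does not show that the chain changes the read-out at all, nor does it give an order among compound 1, compound 2, compound 3 and compound 4.

As far as these compounds go, whether a much shorter chain, or an amine or a carboxylic acid in place of the chain, would give a step beyond the scatter in this assay remains open. Also open, from the compounds shown here alone, is how these compounds compare at other concentrations, as the read-out at a single concentration is not a potency.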